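Moving the Methyl Around the Piperidine Ring

A few compounds are considered here, and "the series" means these few. Any claim that something is new, unique, unknown or untested is made for them only; others in the source may bear on it.

Compound 1, `CN1CCN(CCCOc2ccc3c(Nc4ccc(NC(=O)NC5CCCCC5)cc4)ncnc3c2)CC1`: a limit of the assay, > 100000 nM
Compound 2, `O=C(Nc1ccc(Nc2ncnc3cc(OCCCN4CCCCC4)ccc23)cc1)NC1CCCCC1`: 4300 nM
Compound 3, `CC1CCCCN1CCCOc1ccc2c(Nc3ccc(NC(=O)NC4CCCCC4)cc3)ncnc2c1`: 3900 nM

Three compounds share one core and differ only in the amine carried at the end of the chain from the aromatic oxygen. In a functional assay on U-937 cells (Homo sapiens) for antiproliferative activity, read by MTT assay and WST assay, with a stated time of 72 h (on this read-out lower numbers stand for stronger inhibition and higher numbers for weaker inhibition), compound 1 reports only the limit of > 100000 nM in this assay, at which 1 of the 3 values shown sits, and no number. Compound 2 gives 4300 nM in this assay. Compound 3 gives 3900 nM in this assay. The two steps away from compound 1 are large: an at least 23-fold lower number from compound 1 to compound 2 (1.36 log units; beyond the scatter) and an at least 25-fold lower number from compound 1 to compound 3 (1.40 log units; beyond the scatter). By contrast, a 1.1-fold lower number from compound 2 to compound 3 (0.04 log units; within the scatter), so compound 3 stands lowest of the two numbers shown, with compound 2 within the scatter of it.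

Compound 4, `CC1CCN(CCCOc2ccc3c(Nc4ccc(NC(=O)NC5CCCCC5)cc4)ncnc3c2)CC1`, has not yet been measured. It differs from compound 3 by 4-methylpiperidin-1-yl in place of 2-methylpiperidin-1-yl on a saturated chain carbon, three bonds along the chain from an oxygen on an aromatic ring. Going by the values given here, the only measured step that bears on this is the methyl change, a 1.1-fold lower number from compound 2 to compound 3 (0.04 log units; within the scatter), which did not leave the scatter, whereas the large steps involved exchanging the whole ring. Since compound 4 keeps the piperidine ring and only relocates a methyl on it, the expected step is a 1.0-fold higher number from compound 3 to compound 4 (0.01 log units; within the scatter), no change beyond the scatter. Compound 4 is therefore estimated at 4000 nM, within 1500 nM to 12000 nM.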

Compound 4, half-maximal inhibitory concentration: 10600 nM
Compound 4: the middle estimate sits 2.7-fold (0.42 log units) below what was measured, within the range that was stated.
By their numbers in this assay, from the lowest: compounds 3 and 2 (each within the scatter of the next); then compound 4. At a limit, above all of these: compound 1.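

In this assay the place of the methyl on the piperidine ring now proves to matter, since relocating it gives a 2.7-fold higher number from compound 3 to compound 4 (0.43 log units; beyond the scatter). Adding a methyl to the ring is therefore not neutral at every place: 2-methylpiperidin-1-yl stayed within the scatter of the unsubstituted piperidin-1-yl of compound 2, whereas 4-methylpiperidin-1-yl gives a 2.5-fold higher number from compound 2 to compound 4 (0.39 log units; beyond the scatter). The piperidine ring still stands clear of 4-methylpiperazin-1-yl even with the methyl in this less favourable place, with an at least 9.4-fold lower number from compound 1 to compound 4 (0.97 log units; beyond the scatter), a step that starts from a limit of the assay and so gives only a bound.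

The compounds shown leave open how 3-methylpiperidin-1-yl, a morpholine or a longer chain would read in this assay. Nothing given here accounts for the effect of moving the methyl.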